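The source may report more compounds than this note shows. Statements on the series, on what has been measured and on what is new or still open speak of the compounds shown alone.

Working notes on the series. Within the data shown here, compound 1 `O=C(CN(c1ncnc2c1ncn2C1CCCCO1)C1CC1)N[C@@H](CCC(=O)OCc1ccccc1)C(=O)OCc1ccccc1` and compound 2 `CC[C@H](C)[C@H](NC(=O)CN(c1nc(Cl)nc2[nH]cnc12)C1CC1)C(=O)O` are the two measured members. In a functional assay on the whole organism (Tail, strain ICR) with Mus musculus as the target, in the tail flick test, with a stated time of 30 min, at a dose of 25 umol/kg by the oral route (on this read-out higher numbers stand for a stronger effect at the one dose given and lower numbers for a weaker effect), compound 1 gives 32.6%, and in this assay compound 2 gives 30.3%. Among the measured compounds shown here, compound 2 stands with compound 1 inside the scatter of repeated measurements, so the two numbers show no separation; with only two compounds measured, no step between them is available to set a direction for further changes.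

Compound 3 `O=C(O)CC[C@H](NC(=O)CN(c1nc(Cl)nc2[nH]cnc12)C1CC1)C(=O)O` is unmeasured. It differs from compound 2 as follows: 2-carboxyethyl in place of sec-butyl on a saturated chain carbon bound to an amide-type nitrogen and a carbonyl carbon. The acid group that enters brings a hydrogen-bond donor and acceptor where the sec-butyl carried none.

For the measured compounds named here, no measured step speaks to this change. The expected step in this assay from compound 2 to compound 3 is a number 4.3 percentage points lower from compound 2 to compound 3 (within the scatter), a movement not expected to exceed the scatter by much, with a slight downward lean. Compound 3 is expected to give 26%, within 10% to 42%.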

Compound 3, a percentage reported as activity, at one dose (the size of the read-out at that dose, not a potency): 26.8%
Compound 3: the middle estimate sits 0.8 percentage points below what was measured; measured number inside the range.
By their numbers in this assay, from the lowest: compounds 3, 2 and 1 (each within the scatter of the next).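

In this assay, among these compounds, 2-carboxyethyl in place of sec-butyl on a saturated chain carbon bound to an amide-type nitrogen and a carbonyl carbon gives a number 3.5 percentage points lower from compound 2 to compound 3 (within the scatter) and is the first step that can be read at this position. The read-out therefore does not separate these two groups, although 2-carboxyethyl carries a hydrogen-bond donor and acceptor and sec-butyl carries neither. No measurement at hand bears on the reason for this result.

On these data alone, whether an amine or a longer chain on the same carbon would give a step beyond the scatter remains open. Compound 1 differs from compound 2 and compound 3 in more than one place, so steps to it cannot be read.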